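Replacing 5-nitrothiophen-3-yl with 4-fluorophenyl

The source may report more compounds than this note shows. Statements on the series, on what has been measured and on what is new or still open speak of the compounds shown alone.

In a functional assay on MIA PaCa-2 cells (Homo sapiens) for inhibition, read by MTT assay, with a stated time of 48 h, tested at 10 uM (a lower number here means less inhibition of growth, a higher number more inhibition of growth at the concentration tested), compound 1 `Cc1oc2c([C@H]3CCN(C)C[C@H]3O)c(O)cc(O)c2c(=O)c1C(O)c1cccc(Cl)c1` gives 2%, compound 2 `Cc1oc2c([C@H]3CCN(C)C[C@H]3O)c(O)cc(O)c2c(=O)c1C(O)c1c(F)cccc1Cl` gives 41% and compound 3 `Cc1oc2c([C@H]3CCN(C)C[C@H]3O)c(O)cc(O)c2c(=O)c1C(O)c1csc([N+](=O)[O-])c1` gives 41%. Compound 3 is therefore level with compound 2, and both stand well clear of compound 1. Compound 4 `Cc1oc2c([C@H]3CCN(C)C[C@H]3O)c(O)cc(O)c2c(=O)c1C(O)c1ccc(F)cc1` carries 4-fluorophenyl in place of 5-nitrothiophen-3-yl at the same spot: 4-fluorophenyl in place of 5-nitrothiophen-3-yl on a saturated chain carbon bound to an aromatic carbon and an oxygen on a saturated carbon. Three measured steps changed this group. Two were large, a number 39 percentage points higher from compound 1 to compound 2 (beyond the scatter) and a number 39 percentage points higher from compound 1 to compound 3 (beyond the scatter), while no change at the digits printed from compound 2 to compound 3 (within the scatter) stayed within the scatter. The new group looks most like the 3-chlorophenyl of compound 1, at 2%, so a sizeable drop is expected, though with real uncertainty. The expected change is a number 21 percentage points lower from compound 3 to compound 4 (beyond the scatter). The estimate for compound 4 is 20%, within a range of 2% to 45%.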

Compound 4, percent growth inhibition at one concentration: 17%
Estimate against measurement, compound 4: 3 percentage points above, within the range that was stated.
By their numbers in this assay, from the lowest: compound 1; then compound 4; then compounds 2 and 3 (each within the scatter of the next).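

With 4-fluorophenyl on this carbon, this assay shows a third, middle level rather than just high and low: there is a number 15 percentage points higher from compound 1 to compound 4 (beyond the scatter), but also a number 24 percentage points lower from compound 3 to compound 4 (beyond the scatter) and a number 24 percentage points lower from compound 2 to compound 4 (beyond the scatter). Two phenyl groups carrying a single halogen, in compound 1 and compound 4, therefore still differ beyond the scatter. No measurement shown here explains these differences.

From the compounds shown here alone, what a phenyl ring carrying an amine or a carboxylic acid would give at this position remains open.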